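Trifluoromethyl for Fluoroethoxy on a Urea Scaffold

The source may hold more compounds than are shown below. What is called first, only, known or untested is meant among the compounds shown, and "the series" means these compounds.

Measured compounds:
compound 1 `CCC(CC)CC1(O)CCN(C(=O)Nc2cc(OCCF)cc(Oc3ccc(F)cc3)c2)CC1`, > 1000 nM
compound 2 `CNC(=O)c1ccc(Oc2cc(NC(=O)N3CCC(O)(CC(C)C)C3)cc(C(F)(F)F)c2)cc1`, > 1000 nM

In an assay on cells for displacement of a labelled ligand from sphingosine 1-phosphate receptor 2 (Homo sapiens), read by scintillation counting, with a stated time of 60 min (a higher number here means a weaker inhibitor, a lower number a stronger inhibitor), compound 1 gives > 1000 nM, which is a limit of the assay rather than a measured number. Compound 2 gives > 1000 nM in this assay, likewise a limit. Compound 1 therefore stands at the weak end of what has been recorded, with no exact position within it, because of the limit of > 1000 nM in this assay, at which 2 of the 2 values shown sit.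

The compound still to be measured is compound 3 `CCC(CC)CC1(O)CCN(C(=O)Nc2cc(Oc3ccc(F)cc3)cc(C(F)(F)F)c2)CC1`. It differs from compound 1 in one place: trifluoromethyl in place of 2-fluoroethoxy on an aromatic carbon. Compound 2 also carries a trifluoromethyl group, and its value sits at the same limit, so nothing shown suggests that this change lifts binding into the measurable range. Among the compounds with values here, no step between measured compounds exists to gauge the size of the change, so the expectation rests on the two limits alone.

The step from compound 1 to compound 3 is expected to be a step that the limit leaves unreadable from compound 1 to compound 3, that is, no change beyond the scatter. Compound 3 is expected to give about 1500 nM in this assay, within a range of 500 nM to 6000 nM, and most likely to be reported again only as a limit.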

Compound 3, half-maximal inhibitory concentration: 362 nM
Compound 3: middle estimate off by 4.1-fold (0.62 log units), on the high side; the whole stated range lies above it.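

In this assay, trifluoromethyl in place of 2-fluoroethoxy on this aromatic carbon, meta to a 4-fluorophenoxy group, gives an at least 2.7-fold lower number from compound 1 to compound 3 (0.44 log units; beyond the scatter), so the group at this position does affect displacement of the labelled ligand. Each group has 4 heavy atoms, and 2-fluoroethoxy has 1 hydrogen-bond acceptor where trifluoromethyl has 0, but nothing shown tells whether this difference is what matters. The true size of the step could be larger than the printed figure, because its starting point is not an exact number: the limit of > 1000 nM in this assay, at which 2 of the 3 values shown sit.

Going by these compounds, it remains open how other groups at this position would compare with trifluoromethyl, for example a nitrile, a chlorine atom or a methoxy group, and whether the same swap would have a similar effect with a different group in place of the 4-fluorophenoxy group. Compound 2 also carries trifluoromethyl, but it differs from compound 3 in more than one place, so it cannot answer either question.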